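Thiourea in place of cyanoguanidine on the shorter chain

A few compounds are considered here, and "the series" means these few. Any claim that something is new, unique, unknown or untested is made for them only; others in the source may bear on it.

Measured so far in a functional assay on the whole organism with Rattus norvegicus as the target, at a dose of 100 mg/kg; a higher number here means more inhibition at the dose given (going by the name of the read-out), a lower number less inhibition:
compound 1, `O=c1ccc(-c2ccccc2)nn1CCCCNC(=S)Nc1ccc(Cl)cc1`, gives 43.2%
compound 2, `CCC/N=C(/NC#N)NCCCCn1nc(-c2ccccc2)ccc1=O`, gives 26.3%
compound 3, `N#CNC(=N)NCCCCCCn1nc(-c2ccccc2)ccc1=O`, gives 20.5%

The three compounds share the same core and differ in the chain and in the terminal group on it. Compound 1 carries a thiourea on the shorter chain; compound 2 carries a cyanoguanidine on a chain of the same length; compound 3 carries the cyanoguanidine on a longer chain. In this assay compound 3 and compound 2 sit within the usual scatter of each other, so nothing separates them; compound 1, however, stands clearly higher than compound 3, beyond the scatter.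

Compound 4, `C=CCNC(=S)NCCCCn1nc(-c2ccccc2)ccc1=O`, is not yet measured. Relative to compound 3 the change is a group of 7 heavy atoms (4 carbon, 2 nitrogen, 1 sulfur; no ring) in place of a group of 8 heavy atoms (4 carbon, 4 nitrogen; no ring), on a saturated chain carbon, four bonds along the chain from an aromatic nitrogen. Compound 4 thus returns to the chain length and the thiourea of compound 1, while the group on the far nitrogen is smaller and has no ring. Since compound 1 gives 43.2% with a thiourea on this chain, the step from compound 3 to compound 4 is expected to be upward and of a size likely beyond the scatter, estimated at a number 14.5 percentage points higher from compound 3 to compound 4 (beyond the scatter). For the measured compounds named here, compound 4 is therefore expected at 35%, with a range from 15% to 55%; no measured pair shows the effect of the allyl group itself, so the range is wide.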

Compound 4, a percentage reported as inhibition, in the whole organism at one dose (the size of the read-out at that dose, not a potency): 27.1%
Beside the measured number, compound 4's estimate is 7.9 percentage points above it, and the stated range covers the measured number.
By their numbers in this assay, from the lowest: compounds 3, 2 and 4 (each within the scatter of the next); then compound 1.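

For the compounds shown here, on the shorter chain, the group on the far thiourea nitrogen matters in this assay: allyl in place of 4-chlorophenyl gives a number 16.1 percentage points lower from compound 1 to compound 4 (beyond the scatter) and is the only single-place change so far with a step beyond the scatter. The thiourea on this chain is therefore not enough on its own to reach the level of compound 1, since the allyl thiourea shows a number 0.8 percentage points higher from compound 2 to compound 4 (within the scatter) and a number 6.6 percentage points higher from compound 3 to compound 4 (within the scatter) and both steps stay within the scatter. Compounds 2, 3 and 4 thus form one group in this read-out despite their different terminal groups, while only compound 1 stands apart, and the 4-chlorophenyl thiourea is the one feature that goes with the higher number.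

The compounds shown leave open whether that number needs the ring, the chlorine or both, which a plain phenyl or a propyl on the thiourea would address, and whether a urea in place of the thiourea or the 4-chlorophenyl thiourea on a longer chain would hold it. No measurement at hand accounts for the size of these steps.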